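The source may hold more compounds than are shown below. What is called first, only, known or untested is meant among the compounds shown, and "the series" means these compounds.

- Compound 1 `COC(=O)C1=C(CN2CCNC(=O)C2)NC(c2nccs2)=NC1(C)c1ccc(F)cc1`: 81 mL/min/kg
- Compound 2 `COC(=O)C1=C(CN2CCC(F)(F)CC2)NC(c2nccs2)=NC1(C)c1ccc(F)cc1`: 88 mL/min/kg

In an ADME assay on microsomes from liver (Mus musculus) for metabolic stability, read by LC-MS, using NADPH, with stated times of 10 min and 30 min, tested at 1 uM (on this read-out lower numbers stand for slow clearance and higher numbers for fast clearance), compound 2 gives 88 mL/min/kg. That number lies within the usual scatter of compound 1 at 81 mL/min/kg, so the two cannot be told apart.

Compound 3 `COC(=O)C1=C(CN(C)C2(C(=O)O)CC2)NC(c2nccs2)=NC1(C)c1ccc(F)cc1` keeps the shared core and differs from compound 2 at one place: a group of 8 heavy atoms (5 carbon, 1 nitrogen, 2 oxygen; one three-membered non-aromatic ring of carbon only) in place of a group of 8 heavy atoms (5 carbon, 1 nitrogen, 2 fluorine; one six-membered non-aromatic ring with 1 hetero atom), on a saturated chain carbon bound to a double-bonded ring carbon.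

Among the measured compounds shown here, only one measured step bears on this swap, because it involves the same place: a 1.1-fold higher number from compound 1 to compound 2 (0.04 log units; within the scatter). That step lies within the scatter, so exchanging one group for another here has not yet shifted the number in this assay. However, it is a single step, and the group entering compound 3, with its three-membered ring of carbon only, resembles neither group measured so far. The data therefore give no direct guide to this group, and the expectation below is a judgement with a wide range.

The expected step, toward slower clearance, is a 2.2-fold lower number from compound 2 to compound 3 (0.34 log units; beyond the scatter). The estimate for compound 3 is 40 mL/min/kg, with an expected range of 15 mL/min/kg to 85 mL/min/kg.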

Compound 3, clearance: 42 mL/min/kg
For compound 3 the middle estimate is 1.1-fold (0.02 log units) below the measured one, and the stated range covers the measured number.
By their numbers in this assay, from the lowest: compounds 3, 1 and 2 (each within the scatter of the next, the first and the last beyond it).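

In this assay, among the compounds shown here, this position proves able to shift the number: the group with a three-membered carbon ring, in place of 4,4-difluoropiperidin-1-yl, gives a 2.1-fold lower number from compound 2 to compound 3 (0.32 log units; beyond the scatter) and is the first step here to pass the usual scatter, though only modestly. The same group in place of 3-oxopiperazin-1-yl gives a 1.9-fold lower number from compound 1 to compound 3 (0.29 log units; within the scatter) and so cannot be told apart from that earlier compound, which means the shift can be read against compound 2 only. Nothing measured for these compounds shows why the number moved.

The entering group differs from 4,4-difluoropiperidin-1-yl in several ways at once, including its three-membered ring, its oxygen atoms and its hydrogen-bond donor, so these compounds cannot show which of those features matters. From the compounds shown here alone, it also stays open whether the number would hold or move further with a primary amide or a tetrazole in place of the carboxylic acid of compound 3, or with an open ethyl chain in place of its cyclopropane ring.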